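Swapping a cyclohexyl for an iodinated aromatic ring

This account rests on a few compounds, and the source may have more. Where it says the series, first, only, none or still open, it means among the compounds named here.

Measured compounds:
compound 1 `OC[C@H]1O[C@@H](n2cnc3c(SCC4CCCCC4)ncnc32)[C@H](O)[C@@H]1O` — 1550 nM
compound 2 `O=[N+]([O-])c1ccc(O)c(CSc2ncnc3c2ncn3[C@@H]2O[C@H](CO)[C@@H](O)[C@H]2O)c1` — 33.1 nM
compound 3 `CC(=O)c1cc(Cl)ccc1Sc1nc(N)nc2c1ncn2[C@@H]1O[C@H](CO)[C@@H](O)[C@H]1O` — 14500 nM

Three compounds sharing a nucleoside core were tested in an assay on isolated protein for binding affinity to Equilibrative nucleoside transporter 1 (Homo sapiens); on this read-out higher numbers stand for weaker inhibition and lower numbers for stronger inhibition. Compound 1 gives 1550 nM, the second highest of the three numbers: compound 3 lies above it, and compound 2 sits far below. Among the measured compounds shown here, the single measured step that alters the same position runs from compound 1 to compound 2, where a 47-fold lower number from compound 1 to compound 2 (1.67 log units; beyond the scatter) accompanies a 2-hydroxy-5-nitrophenyl in place of a cyclohexyl on a saturated chain carbon bound to a sulfur.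

Compound 4 `OC[C@H]1O[C@@H](n2cnc3c(CSc4ccccc4I)ncnc32)[C@H](O)[C@@H]1O` is not yet measured. Relative to compound 1 it carries a group of 9 heavy atoms (7 carbon, 1 sulfur, 1 iodine; one six-membered aromatic ring of carbon only) in place of a group of 8 heavy atoms (7 carbon, 1 sulfur; one six-membered non-aromatic ring of carbon only), on an aromatic carbon. For the measured compounds named here, the sulfur now sits beyond the chain carbon rather than before it, and the aromatic ring bears iodine instead of hydroxyl and nitro groups; no measured pair shows these exact changes. Because a 47-fold lower number from compound 1 to compound 2 (1.67 log units; beyond the scatter) was large when an aromatic ring replaced the cyclohexyl, compound 4 is expected to give a lower number than compound 1, though the step is estimated smaller than that one, at a 5.2-fold lower number from compound 1 to compound 4 (0.71 log units; beyond the scatter). Compound 4 is therefore estimated at 300 nM, within a range of 60 nM to 1500 nM.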

Compound 4, half-maximal inhibitory concentration: 282 nM
For compound 4 the middle estimate is 1.1-fold (0.03 log units) above the measured one, and the stated range covers the measured number.
By their numbers in this assay, from the lowest: compound 2; then compound 4; then compound 1; then compound 3.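

In this assay, the group with the iodinated aromatic ring gives a 5.5-fold lower number from compound 1 to compound 4 (0.74 log units; beyond the scatter). With a 47-fold lower number from compound 1 to compound 2 (1.67 log units; beyond the scatter), this shows that a lower number than that of compound 1 at this aromatic carbon of the core does not depend on the hydroxyl and nitro groups of compound 2, nor on the sulfur being bound directly to the core as it is in compound 2. No measurement here explains why either aromatic group goes with a lower number than the cyclohexyl group.

Compound 4 moves the sulfur and changes the ring at once, so the share of each change in the step cannot be separated. The compounds shown also leave open how an unsubstituted phenyl ring, or a bromine in place of the iodine, would read out at this position.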